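Diethylamino in place of fluoro: an expected cytotoxicity step

The compounds below may be only part of what the source reports. "The series", "measured", "known", "first", "only" and "open" are said of these compounds alone.

Three compounds have been measured in an ADME assay on L6 cells (Rattus norvegicus) for cytotoxicity, read by resazurin assay, with a stated time of 72 h; on this read-out lower numbers stand for stronger inhibition and higher numbers for weaker inhibition:
compound 1 `CCc1ccc(C(=O)NC(=O)c2ccccc2O)cc1` gives 70 ug/mL;
compound 2 `O=C(NC(=O)c1ccccc1O)c1ccc(F)cc1` gives 38 ug/mL;
compound 3 `CN(C)c1ccc(C(=O)NC(=O)c2ccccc2O)cc1` gives 54 ug/mL.

Compound 2 has the lowest number of the three, though its nearest neighbour is compound 3 (a 1.4-fold higher number from compound 2 to compound 3 (0.15 log units; within the scatter)) and its furthest is compound 1 (a 1.8-fold lower number from compound 1 to compound 2 (0.27 log units; within the scatter)), both within the scatter. Compound 4 `CCN(CC)c1ccc(C(=O)NC(=O)c2ccccc2O)cc1` has not yet been measured. It differs from compound 2 by diethylamino in place of fluoro on an aromatic carbon. The step that bears most directly on it is a 1.4-fold higher number from compound 2 to compound 3 (0.15 log units; within the scatter), and a 1.3-fold lower number from compound 1 to compound 3 (0.11 log units; within the scatter) shows the same place tolerating a change without leaving the scatter. Compound 4 is therefore expected to give a number near that of compound 2, with a 1.3-fold higher number from compound 2 to compound 4 (0.12 log units; within the scatter), so the estimate for compound 4 is 50 ug/mL, ranging from 25 ug/mL to 100 ug/mL.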

Compound 4, half-maximal inhibitory concentration: 8.2 ug/mL
Compound 4: middle estimate off by 6.1-fold (0.79 log units), on the high side, outside the stated range (below it).
By their numbers in this assay, from the lowest: compound 4; then compounds 2, 3 and 1 (each within the scatter of the next).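

In this assay, ethyl, fluoro and dimethylamino at this position had stayed within the scatter of one another, but diethylamino moves the number beyond it (the steps are a 4.6-fold lower number from compound 2 to compound 4 (0.67 log units; beyond the scatter) and an 8.5-fold lower number from compound 1 to compound 4 (0.93 log units; beyond the scatter)). The change is also sharp between the two amines, with only the groups on nitrogen differing (a 6.6-fold lower number from compound 3 to compound 4 (0.82 log units; beyond the scatter)). No available evidence accounts for this step.

On these data alone, whether the lower number persists with a longer chain on the nitrogen, as in dipropylamino, or with a cyclic amine such as piperidinyl remains open.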